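A 4-chlorophenyl in place of the sulfonyl ester

This account rests on a few compounds, and the source may have more. Where it says the series, first, only, none or still open, it means among the compounds named here.

Compound 1 `C=C[C@@](C)(/C=C/c1ccc(OS(=O)(=O)C(F)(F)F)cc1)CCC=C(C)C` is the starting point. In an ADME assay on BJ cells (Homo sapiens) for cytotoxicity, with a stated time of 72 h (on this read-out higher numbers stand for an effect only at larger amounts of compound and lower numbers for an effect already at smaller amounts), compound 1 gives > 36600 nM, which is a limit of the assay rather than a number. Compound 2 `C=C[C@@](C)(/C=C/c1ccc(OS(=O)(=O)c2ccc(C)cc2)cc1)CCC=C(C)C` likewise gives > 36600 nM in this assay, again only a limit. Compound 3 `C=C[C@@](C)(/C=C/c1ccc(Nc2cc(C(F)(F)F)cc(C(F)(F)F)c2)cc1)CCC=C(C)C` also reaches only the limit > 36600 nM in this assay. The step that the two limits leave unreadable from compound 1 to compound 2 therefore cannot be read, and every value shown sits at the limit of > 36600 nM in this assay, at which 3 of the 3 values shown sit. Compound 4 `C=C[C@@](C)(/C=C/c1ccc(-c2ccc(Cl)cc2)cc1)CCC=C(C)C` differs from compound 1 by 4-chlorophenyl in place of ((trifluoromethyl)sulfonyl)oxy on an aromatic carbon. Going by the values given here, no measured step bears on this change, so no size can be read for it; because every measured value sits at the limit of > 36600 nM in this assay, at which 3 of the 3 values shown sit, compound 4 is expected to stay at or near that limit too, with an expected step that the limit leaves unreadable from compound 1 to compound 4. The value of compound 4 in this assay is estimated at 45000 nM, ranging from 15000 nM to 120000 nM.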

Compound 4, half-maximal effective concentration: > 36600 nM
Compound 4: only a limit was reported; the forecaster's own chance of this, stated with the estimate: 75%; the middle value lies beyond the limit too.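

In this assay compound 4 gives > 36600 nM and this is only a limit, as for compound 1, so no step between compound 1 and compound 4 can be read: the limit of > 36600 nM in this assay, at which 4 of the 4 values shown sit.

The compounds shown leave open at what concentration any of them would affect these cells, and so how their groups compare.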